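Working notes: from compound 2 to compound 4

This account rests on a few compounds, and the source may have more. Where it says the series, first, only, none or still open, it means among the compounds named here.

- compound 1 `C#CCSc1nc(Sc2ccccn2)c(C#N)c(-c2cc(OC)c(OC)c(OC)c2)n1`: > 10000 nM
- compound 2 `C#CCSc1nc(Sc2nccs2)c(C#N)c(-c2ccc(Br)cc2)n1`: 10900 nM
- compound 3 `C#CCSc1nc(Sc2nc3ccccc3s2)c(C#N)c(-c2cc(OC)c(OC)c(OC)c2)n1`: > 20000 nM

For the measured compounds named here, in a functional assay on KYSE-70 cells for antiproliferative activity against KYSE-70 cell line (Homo sapiens), read by MTT assay, with a stated time of 72 h (a lower number here means a stronger inhibitor, a higher number a weaker inhibitor), compound 2 gives 10900 nM, the only actual number among the three. The entry for compound 1 is a limit. The entry for compound 3 is also a limit.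

Compound 4 `C#CCSc1nc(Sc2nccs2)c(C#N)c(-c2ccc[nH]2)n1` differs from compound 2 as follows: 1H-pyrrol-2-yl in place of 4-bromophenyl on an aromatic carbon. In short, 1H-pyrrol-2-yl replaces 4-bromophenyl on an aromatic carbon.

Going by the values given here, the only measured step, a step that the two limits leave unreadable from compound 1 to compound 3, concerns a group on a sulfur rather than this aromatic carbon, and its size cannot be read. Among the compounds with values here, no measured step therefore bears directly on the change, and no direction can be assigned. The expectation rests on compound 2 at 10900 nM. The expected outcome is a 1.1-fold lower number from compound 2 to compound 4 (0.04 log units; within the scatter), with no shift beyond the scatter anticipated. The estimate for compound 4 is 10000 nM, expected to fall between 2500 nM and 30000 nM.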

Compound 4, half-maximal inhibitory concentration: > 20000 nM
Compound 4: no number, only a limit; the forecaster's own chance of this, stated with the estimate: 35%; at least 2.0-fold (0.30 log units) between middle value and limit.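

In this assay compound 4 gives > 20000 nM, which is a limit of the assay and not a number. At this aromatic carbon, the exchange of 4-bromophenyl for 1H-pyrrol-2-yl is an at least 1.8-fold higher number from compound 2 to compound 4 (0.26 log units; that floor lies within the scatter), the first step shown at this position, so the change brings no measurable gain, while its true size stays unread and compound 2 keeps the only actual number in the set. Compound 4 sits at a limit shared within the series: the limit of > 20000 nM in this assay, at which 2 of the 4 values shown sit.

The step between compound 1 and compound 3 cannot be read. From the compounds shown here alone, it remains open whether any group at this carbon, such as 4-aminophenyl or 4-carboxyphenyl, would give a number clearly lower than that of compound 2, and whether the 4-bromo substituent itself matters.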